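The compounds below may be only part of what the source reports. "The series", "measured", "known", "first", "only" and "open" are said of these compounds alone.

In a functional assay on MDA-MB-231 cells (Homo sapiens) for antiproliferative activity, read by MTT assay, with a stated time of 72 h (on this read-out lower numbers stand for stronger inhibition and higher numbers for weaker inhibition), compound 1 `CC(=O)O[C@H]1CC[C@]2(C)[C@H](CC[C@@](C)(O)[C@H]2CC[C@@H]2C(C)=CC[C@H]3[C@H](CC[C@]3(C)O)C2(C)C)OC1(C)C` gives 38000 nM, the second highest of three numbers; compound 2 `CC(=O)O[C@H]1CC[C@]2(C)[C@H](CC[C@@](C)(O)[C@H]2CC[C@@H]2C(C)=CC[C@H]3[C@H](CC[C@]3(C)OC(C)=O)C2(C)C)OC1(C)C` gives 26200 nM and compound 3 `CC(=O)O[C@H]1CC[C@]2(C)[C@H](CC[C@@](C)(O)[C@H]2CC[C@@H]2C(C)=CC[C@@H]3C(C)=CC[C@@H]3C2(C)C)OC1(C)C` gives 39200 nM, both within the scatter of compound 1. Compound 4 `COc1ccc(C(=O)O[C@H]2CC[C@]3(C)[C@H](CC[C@@](C)(O)[C@H]3CC[C@@H]3C(C)=CC[C@H]4[C@H](CC[C@]4(C)O)C3(C)C)OC2(C)C)cc1` differs from compound 1 by 4-methoxyphenyl in place of methyl on a carbonyl carbon. Among the measured compounds shown here, no measured step alters this ester group itself. For the measured compounds named here, the only measured step, a 1.5-fold lower number from compound 1 to compound 2 (0.16 log units; within the scatter), concerns a different site and stays within the scatter, and compound 3 differs from compound 1 at a site far from this ester and also stays within the scatter. Nothing here shows the numbers responding to structural change at all, so compound 4 is expected to give 32000 nM, within 12000 nM to 85000 nM, and the step of a 1.2-fold lower number from compound 1 to compound 4 (0.07 log units; within the scatter) is expected to stay within the scatter.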

Compound 4, half-maximal inhibitory concentration: 30600 nM
For compound 4 the middle estimate is 1.0-fold (0.02 log units) above the measured one; the range from low to high includes it.
By their numbers in this assay, from the lowest: compounds 2, 4, 1 and 3 (each within the scatter of the next).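

Among the compounds shown here, this is the first measured change at the ester itself: in this assay, the step from acetyl to (4-methoxyphenyl)carbonyl, which adds an aromatic ring, gives a 1.2-fold lower number from compound 1 to compound 4 (0.09 log units; within the scatter). So this position accepts a much larger group on the carbonyl carbon with no change in the read-out beyond the scatter. Nothing measured here offers an explanation for this.

Still open, from the compounds shown here alone, is whether a different kind of group on this carbonyl carbon, such as an amine or a longer chain ending in a carboxylic acid, would move the number beyond the scatter. Also open, going by these compounds, is whether a free hydroxyl in place of the whole ester would do so.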